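Trimming the aryl amide of compound 1 to an acetyl

The source may report more compounds than this note shows. Statements on the series, on what has been measured and on what is new or still open speak of the compounds shown alone.

Measured so far:
compound 1 `COc1ccc(Cl)cc1C(=O)NCCC1CCN(S(=O)(=O)NC(=O)NC[C@@H]2C[C@@H]3C=C[C@@H]2C3)CC1` gives 37%
compound 2 `CCCNC(=O)NS(=O)(=O)N1CCC(CCNC(=O)c2cc(Cl)ccc2OC)CC1` gives 11%
compound 3 `COc1ccc(Cl)cc1C(=O)NCCC1CCN(S(=O)(=O)NC(=O)NN2CCCCCC2)CC1` gives 36%

In a functional assay on the whole organism (blood) with Rattus norvegicus as the target, with stated times of 24 h and 1 h, at a dose of 5 mg/kg by the intraperitoneal route (a higher number here means a stronger effect of the compound at the dose given, a lower number a weaker effect), compound 1 has the highest of the three numbers; compound 3 lies within the scatter of it (a number 1 percentage points lower from compound 1 to compound 3 (within the scatter)), whereas compound 2 is further off (a number 26 percentage points lower from compound 1 to compound 2 (beyond the scatter)). Compound 4 `CC(=O)NCCC1CCN(S(=O)(=O)NC(=O)NC[C@@H]2C[C@@H]3C=C[C@@H]2C3)CC1` differs from compound 1 at the other end of the shared core: methyl in place of 5-chloro-2-methoxyphenyl on a carbonyl carbon. For the measured compounds named here, each measured step, a number 26 percentage points lower from compound 1 to compound 2 (beyond the scatter) and a number 25 percentage points higher from compound 2 to compound 3 (beyond the scatter), alters only the urea end; no measured step touches the carbonyl end, so nothing directly shows what this change does. As the leaving group is kept in all three measured compounds, a weaker effect is expected, a number 22 percentage points lower from compound 1 to compound 4 (beyond the scatter), with wide uncertainty. Compound 4 is estimated at 15%, between 0% and 40%.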

Compound 4, a percentage reported as activity, at one dose (the size of the read-out at that dose, not a potency): 18%
Beside the measured number, compound 4's estimate is 3 percentage points below it; the range from low to high includes it.
By their numbers in this assay, from the lowest: compounds 2 and 4 (each within the scatter of the next); then compounds 3 and 1 (each within the scatter of the next).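

Compound 4 carries acetyl in place of the (5-chloro-2-methoxyphenyl)carbonyl of compound 1. In this assay the step is a number 19 percentage points lower from compound 1 to compound 4 (beyond the scatter). The carbonyl end of the molecule therefore also shapes the effect at the dose given, even with the urea end of compound 1 left intact. The data offer no explanation for this drop.

As far as these compounds go, it remains open whether a plain phenyl ring or a longer chain on the carbonyl carbon would recover the effect, and which part of the 5-chloro-2-methoxyphenyl group counts. From the compounds shown here alone, the same change also remains untested with the azepan-1-yl group of compound 3.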